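Chloro Added Beside Fluorine on the Aryl Group of Compound 1

This account rests on a few compounds, and the source may have more. Where it says the series, first, only, none or still open, it means among the compounds named here.

Measured compounds:
- compound 1, `C[C@H](c1ccc(C(=O)NCCC(=O)O)cc1)N1C(=O)C(c2ccccc2F)=N[C@]12CC[C@@H](C(C)(C)C)CC2`: 1100 nM
- compound 2, `CC(C)(C)CC[C@H](c1ccc(C(=O)NCc2nn[nH]n2)cc1)N1C(=O)C(c2cccc(C(F)(F)F)c2)=N[C@]12CC[C@@H](C(C)(C)C)CC2`: 13 nM
- compound 3, `CCCCC[C@H](c1ccc(C(=O)NCc2nn[nH]n2)cc1)N1C(=O)C(c2cc(Cl)cc(Cl)c2)=N[C@]12CC[C@@H](C(C)(C)C)CC2`: 24 nM

Of the compounds shown here, three sharing one core have been measured in an assay on CHO cells for displacement of a labelled ligand from Glucagon receptor (Homo sapiens), read by scintillation counting, with a stated time of 60 min; on this read-out higher numbers stand for weaker inhibition and lower numbers for stronger inhibition. Compound 1 gives 1100 nM, the highest of the three numbers. Its nearest neighbour is compound 3, which in this assay gives 24 nM, a number well beyond the usual scatter away from compound 1. Compound 2 stands furthest off, with 13 nM in this assay, again clearly beyond the scatter. For the measured compounds named here, compounds 2 and 3 differ from compound 1 in several places at once, so no single step between measured compounds is available.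

Compound 4, `C[C@H](c1ccc(C(=O)NCCC(=O)O)cc1)N1C(=O)C(c2cccc(Cl)c2F)=N[C@]12CC[C@@H](C(C)(C)C)CC2`, is not yet measured. It differs from compound 1 by one change: chloro in place of hydrogen on an aromatic carbon. Cut one bond further out, the difference reads 2-fluorophenyl to 3-chloro-2-fluorophenyl.

Going by the values given here, with no measured step of the same kind to lean on, the expectation rests on the weak starting point of compound 1. A modest gain is expected, so that the step of a 2.2-fold lower number from compound 1 to compound 4 (0.34 log units; beyond the scatter) is estimated to fall towards a lower number, of a size near the edge of the scatter. Compound 4 is therefore expected to give about 500 nM, with a range from 150 nM to 1500 nM.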

Compound 4, half-maximal inhibitory concentration: 620 nM
For compound 4 the middle estimate is 1.2-fold (0.09 log units) below the measured one; the range from low to high includes it.
By their numbers in this assay, from the lowest: compounds 2 and 3 (each within the scatter of the next); then compounds 4 and 1 (each within the scatter of the next).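

In this assay, for the compounds shown here, the step for chloro in place of hydrogen on the aromatic carbon ortho to the fluoro group, a 1.8-fold lower number from compound 1 to compound 4 (0.25 log units; within the scatter), is the first single-place step available for this series. It shows that the 2-fluorophenyl group of compound 1 can carry this one extra chlorine atom as 3-chloro-2-fluorophenyl with a result that cannot be told apart from the scatter, so this change at this position neither clearly helps nor clearly harms the reading on its own. Nothing measured here bears on why the step has this size.

The compounds shown leave open whether another group at this position, such as bromo, methyl, methoxy or an amine, would move the number beyond the scatter, so this single chloro step does not describe the position as a whole. They also leave open whether chloro at this position gives a similar step when the fluoro group is absent, or when the carboxylic acid chain of compound 4 is replaced by a tetrazole-bearing amide.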